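The source may report more compounds than this note shows. Statements on the series, on what has been measured and on what is new or still open speak of the compounds shown alone.

Compounds measured in a functional assay on the whole organism with Mus musculus as the target; a higher number here means that more compound is needed for the effect, a lower number that less compound is needed:
compound 1, `CCCC[C@@](C)(OC)[C@H](O)/C=C/C1[C@H](O)C[C@H](O)[C@@H]1C/C=C\CCCC(=O)OC` — 0.888 mg/kg
compound 2, `CCCC[C@](C)(OC)[C@@H](O)/C=C/C1[C@H](O)CC(=O)[C@@H]1C/C=C\CCCC(=O)OC` — 0.912 mg/kg
compound 3, `CCCC[C@](C)(OC)[C@@H](O)/C=C/C1[C@H](O)CC(=O)[C@@H]1CCCCCCC(=O)OC` — > 4 mg/kg; 0.774 mg/kg (2 entries)

In this assay compound 1 gives the lowest of the two single numbers, yet its nearest neighbour, compound 2, lies at 0.912 mg/kg, a gap within the usual scatter, so the two cannot be ranked against each other. Compound 3 is a different case: one of its entries is a limit of the assay rather than a number, as the record the several entries of compound 3 in this assay, > 4 mg/kg; 0.774 mg/kg (2 entries) shows, while its other entry is a number close to those of compound 1 and compound 2.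

The step followed here leads from compound 1 to compound 4, `CCCC[C@@](C)(OC)[C@@H](O)/C=C/C1[C@H](O)C[C@H](O)[C@@H]1C/C=C\CCCC(=O)OC`, which has not yet been measured in this assay. The difference between them is the two compounds have the same atoms and bonds; at least one stereo element is drawn with a configuration in one of them and without one in the other: 1 of 8 stereo elements differ; a stereocentre at a saturated chain carbon is drawn R in compound 1 and S in compound 4. Among the measured compounds shown here, no step between two measured compounds of this kind is available, so there is nothing in the measured data to tell how large an effect such an inversion has.

The expectation is a move toward a higher dose, beyond the scatter, with an estimated step of a 2.8-fold higher number from compound 1 to compound 4 (0.45 log units; beyond the scatter). Compound 4 is therefore expected to give about 2.5 mg/kg, in a range from 0.8 mg/kg to 8 mg/kg.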

Compound 4, dose for half-maximal effect: > 4 mg/kg
Compound 4: no number, only a limit; the forecaster's own chance of this, stated with the estimate: 20%; middle value at least 1.6-fold (0.20 log units) away from the limit.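

Among the earlier compounds no step of this kind could be read, so they gave no sign of whether the configuration at this saturated chain carbon matters in this assay. With atoms and bonds unchanged, the inversion of this one stereocentre now gives an at least 4.5-fold higher number from compound 1 to compound 4 (0.65 log units; beyond the scatter), so the configuration here does count in this whole-organism read-out, and the step lies beyond the scatter. For compound 4 the entry > 4 mg/kg is a limit of the assay and not a number, so the step fixes only a minimum size, and the same limit also appears in the record of another compound of the series: the several entries of compound 3 in this assay, > 4 mg/kg; 0.774 mg/kg (2 entries)

The compounds shown leave open how large the step really is, and whether the same inversion would act alike in compound 2 or compound 3, or with an ethoxy group in place of the methoxy group on this carbon. The reading of the step as a true inversion also carries a caution about how the two structures are drawn: the fact that one of compounds 1 and 4 is drawn with a defined configuration and the other without, at the place where they differ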